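Flipping One Stereocentre in a Cytotoxicity Series

The source may report more compounds than this note shows. Statements on the series, on what has been measured and on what is new or still open speak of the compounds shown alone.

Three measured compounds share a core and differ only at the aryl group. Compound 1 `Cc1ccc(-c2ccc(C(=O)N[C@@H](c3nc(C)c(CCO)s3)[C@@H]3CCCCN3)[nH]2)cc1F` gives 15300 nM in a toxicity assay on TZM cells (Homo sapiens) for cytotoxicity, read by XTT assay, with a stated time of 3 days; a higher number here means that more compound is tolerated, a lower number that less compound is tolerated. Compound 2 `Cc1nc([C@H](NC(=O)c2ccc(-c3ccc(Cl)c(F)c3)[nH]2)[C@@H]2CCCCN2)sc1CCO` gives 15100 nM in this assay, and the step of a 1.0-fold lower number from compound 1 to compound 2 (0.01 log units; within the scatter) shows that swapping the aryl substituent changed nothing beyond the scatter. Compound 3 `Cc1nc([C@@H](NC(=O)c2ccc(-c3ccc(Cl)cc3)[nH]2)[C@@H]2CCCCN2)sc1CCO` gives 17300 nM in this assay, the highest of the three numbers, yet it sits within the scatter of both compound 1 and compound 2, so no ordering among them can be claimed.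

Compound 4 `Cc1nc([C@H](NC(=O)c2ccc(-c3ccc(Cl)cc3)[nH]2)[C@@H]2CCCCN2)sc1CCO` is the stereoisomer of compound 3: the two compounds have the same atoms and bonds and differ only in configuration as drawn: 1 of 2 stereo elements differ; a stereocentre at a saturated chain carbon is drawn S in compound 3 and R in compound 4. Within the data shown here, none of the measured steps involves a change of configuration, so the only guide is that every change seen so far, including the step from compound 1 to compound 2, left this assay unmoved. The step of a 1.1-fold lower number from compound 3 to compound 4 (0.03 log units; within the scatter) is therefore expected to stay within the scatter. For compound 4 the estimated value in this assay is 16000 nM, with a range from 8000 nM to 32000 nM.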

Compound 4, half-maximal cytotoxic concentration: 15400 nM
Compound 4: middle estimate off by 1.0-fold (0.02 log units), on the high side, within the range that was stated.
By their numbers in this assay, from the lowest: compounds 2, 1, 4 and 3 (each within the scatter of the next).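

Compounds 3 and 4 give the first test of configuration in this series, and the comparison isolates that single feature: the fact that compounds 3 and 4 differ only in the configuration as drawn In this assay, drawing the stereocentre at the saturated chain carbon as R rather than S gives a 1.1-fold lower number from compound 3 to compound 4 (0.05 log units; within the scatter), so tolerance in these cells does not distinguish the two forms at this position. The aryl changes that end at compound 4 also stay within the scatter, with hydrogen in place of fluoro giving a 1.0-fold higher number from compound 2 to compound 4 (0.01 log units; within the scatter) and 4-chlorophenyl in place of 3-fluoro-4-methylphenyl giving a 1.0-fold higher number from compound 1 to compound 4 (0.00 log units; within the scatter).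

As far as these compounds go, only one of the two stereo elements differs between compound 3 and compound 4, so the other remains untested here. From the compounds shown here alone, whether an amine or a carboxylic acid on the aryl group would shift the number in this assay also remains open.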